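A Second Phenyl on the Ether Carbon of Compound 2

The compounds below may be only part of what the source reports. "The series", "measured", "known", "first", "only" and "open" are said of these compounds alone.

Measured so far in an assay on membranes from brain for binding affinity to Fatty-acid amide hydrolase 1 (Mus musculus), read by fluorescence, with stated times of 1 h and 30 min; a higher number here means a weaker inhibitor, a lower number a stronger inhibitor:
- compound 1 `O=C(NCc1ccc(OCc2ccccc2)cc1)n1cccn1` gives 800 nM
- compound 2 `N#Cc1cnn(C(=O)NCc2ccc(OCc3ccccc3)cc2)c1` gives 60 nM
- compound 3 `CN(CCN(C)C(=O)n1cccn1)Cc1ccc(OCc2ccccc2)cc1` gives 510 nM

Compound 2 stands lowest of the three numbers in this assay. Among the compounds with values here, the only single-point step among them, a 13-fold lower number from compound 1 to compound 2 (1.12 log units; beyond the scatter), shows how much the cyano group on the aromatic carbon pulled the number down. Compound 3 differs from compound 2 in more than one place, so its higher value says nothing about any one change.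

Compound 4 `N#Cc1cnn(C(=O)NCc2ccc(OC(c3ccccc3)c3ccccc3)cc2)c1` is compound 2 with one change: phenyl in place of hydrogen on a saturated chain carbon bound to an aromatic carbon and an oxygen on an aromatic ring. Within the data shown here, no measured step touches this part of the molecule; the one step known, a 13-fold lower number from compound 1 to compound 2 (1.12 log units; beyond the scatter), concerns a different position. With no guide from the data, the expectation for compound 4 is a change no larger than the scatter, no change at the digits printed from compound 2 to compound 4 (within the scatter), though the range must be wide. The estimated value for compound 4 in this assay is 60 nM, expected between 15 nM and 250 nM.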

Compound 4, half-maximal inhibitory concentration: > 100000 nM
Compound 4 gave a limit, no number; the forecaster's own chance of this, stated with the estimate: 5%; middle value at least 1600-fold (3.22 log units) from the limit.
By their numbers in this assay, from the lowest: compound 2; then compounds 3 and 1 (each within the scatter of the next). At a limit, above all of these: compound 4.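

In this assay, phenyl in place of hydrogen on a saturated chain carbon bound to an aromatic carbon and an oxygen on an aromatic ring gives an at least 1600-fold higher number from compound 2 to compound 4 (3.22 log units; beyond the scatter). Compound 4 reaches a limit of the assay and has no exact number: > 100000 nM. The earlier compounds shown here showed only what the cyano group does, whereas this step shows that the ether carbon also matters greatly, and that keeping the cyano group does not preserve the low number of compound 2 once this second phenyl is present.

As far as these compounds go, it remains open whether a single methyl on the same carbon would be accepted, or whether this carbon must keep both of its hydrogens. Also open, from the compounds shown here alone, is whether an amine or a carboxylic acid in place of the second phenyl would bring the number back towards that of compound 2.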